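Swapping Furan for Thiophene on a Nucleoside Core

This account rests on a few compounds, and the source may have more. Where it says the series, first, only, none or still open, it means among the compounds named here.

Of the compounds shown here, three that share a sugar-bearing bicyclic core have been tested in a functional assay on HL-60 cells (Homo sapiens) for antiproliferative activity, read by XTT assay, with a stated time of 72 h; a lower number here means a stronger inhibitor, a higher number a weaker inhibitor. Compound 1 `Cc1nc(N)c2c(-c3cccs3)cn([C@@H]3O[C@H](CO)[C@@H](O)[C@H]3O)c2n1` carries a thiophen-2-yl group, and compound 2 `Cc1nc(N)c2c(-c3ccco3)cn([C@@H]3O[C@H](CO)[C@@H](O)[C@H]3O)c2n1` the corresponding furan-2-yl group. Compound 3 `Nc1nc2c(c(-c3ccco3)cn2[C@@H]2O[C@H](CO)[C@@H](O)[C@H]2O)c(=O)[nH]1` has the furan-2-yl group as well, but on a different core; how the core of compound 3 differs from that of compound 2 is not broken down here.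

In this assay compound 1 reaches only the limit of the assay, > 20000 nM. Compound 2 likewise gives only a limit, > 20000 nM. Compound 3 also stops at a limit, > 20000 nM. The change from compound 2 to compound 1, (thiophen-2-yl in place of furan-2-yl on an aromatic carbon), therefore gives a step that the two limits leave unreadable from compound 2 to compound 1, so the two limits say nothing about its size.

Compound 4 `Nc1nc2c(c(-c3cccs3)cn2[C@@H]2O[C@H](CO)[C@@H](O)[C@H]2O)c(=O)[nH]1` is not yet measured. It stands to compound 3 as compound 1 stands to compound 2: thiophen-2-yl in place of furan-2-yl on an aromatic carbon, the same kind of change at the same kind of place. Going by the values given here, the step that the limit leaves unreadable from compound 3 to compound 4 is expected to be small or unreadable, because the limit of > 20000 nM in this assay, at which 3 of the 3 values shown sit, leaves every measured compound at the same limit and the one measured instance of this change, a step that the two limits leave unreadable from compound 2 to compound 1, gave no visible movement. Compound 4 is therefore expected to give 30000 nM in this assay, most likely reported again only as a limit, with an expected range from 10000 nM to 100000 nM.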

Compound 4, half-maximal inhibitory concentration: > 20000 nM
Compound 4: no number, only a limit; the forecaster's own chance of this, stated with the estimate: 85%; the middle value is on the limit's open side.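

In this assay compound 4 gives > 20000 nM, which is a limit of the assay and not a number. No step from compound 3 to compound 4 can be read, because both compounds stop at the same limit: the limit of > 20000 nM in this assay, at which 4 of the 4 values shown sit.

The compounds shown leave open whether thiophen-2-yl in place of furan-2-yl changes activity at all on either core, and how strong any of the four compounds actually is.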